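The source may hold more compounds than are shown below. What is called first, only, known or untested is meant among the compounds shown, and "the series" means these compounds.

Working notes on the series. In a functional assay on NCI/ADR-RES cells (Homo sapiens) for inhibition, read by sulforhodamine B assay, with a stated time of 48 h (a lower number here means a stronger inhibitor of growth, a higher number a weaker inhibitor of growth), compound 1 `CC1=CC[C@H](C(C)(C)NC(=S)N/N=C/c2ccccc2)CC1` sits at the limit of > 100000 nM in this assay, at which 1 of the 3 values shown sits, and its value > 100000 nM is a limit rather than a number. Compound 2 `CC1=CC[C@H](C(C)(C)NC(=S)N/N=C/c2ccc(O)cc2)CC1` gives 82100 nM in this assay, and compound 3 `CC1=CC[C@H](C(C)(C)NC(=S)N/N=C/c2cccc(Cl)c2)CC1` gives 67500 nM. Compound 3 thus holds the lowest of the two numbers, though compound 2 lies within the scatter of it. Compound 4 `CC1=CC[C@H](C(C)(C)NC(=S)N/N=C/c2ccco2)CC1` carries furan-2-yl in place of 3-chlorophenyl on a carbon with a double bond to nitrogen. The closest measured step is the exchange of one ring for another, a 1.2-fold lower number from compound 2 to compound 3 (0.09 log units; within the scatter), within the scatter; the steps of an at least 1.2-fold lower number from compound 1 to compound 2 (0.08 log units; that floor lies within the scatter) and an at least 1.4-fold lower number from compound 1 to compound 3 (0.17 log units; that floor lies within the scatter) have floors within the scatter as well. A further ring exchange is therefore expected to give no step beyond the scatter, a 1.1-fold higher number from compound 3 to compound 4 (0.05 log units; within the scatter). Compound 4 is estimated at 75000 nM, between 30000 nM and 190000 nM.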

Compound 4, concentration for 50% growth inhibition: 9800 nM
The estimate for compound 4 lay 7.7-fold (0.88 log units) above the measured number; measured number outside the range, below it.
By their numbers in this assay, from the lowest: compound 4; then compounds 3 and 2 (each within the scatter of the next). At a limit, above all of these: compound 1.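

At this position, on a carbon with a double bond to nitrogen, the ring exchange now produces steps beyond the scatter: a 6.9-fold lower number from compound 3 to compound 4 (0.84 log units; beyond the scatter) and an 8.4-fold lower number from compound 2 to compound 4 (0.92 log units; beyond the scatter), whereas the exchange between the two substituted phenyl rings stayed within it. Against the unsubstituted phenyl, the step is an at least 10-fold lower number from compound 1 to compound 4 (1.00 log units; beyond the scatter), and it is only a floor. Nothing shown bears on the cause of this change.

On these data alone, whether the gain follows the ring oxygen or the five-membered ring remains open. Thiophen-2-yl or pyrrol-2-yl at this position would separate the two.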